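The source may hold more compounds than are shown below. What is called first, only, known or untested is meant among the compounds shown, and "the series" means these compounds.

Within the data shown here, in a functional assay on PC-12 cells (Rattus norvegicus) for cytotoxicity, read by MTT assay, with a stated time of 24 h (on this read-out lower numbers stand for an effect already at smaller amounts and higher numbers for an effect only at larger amounts of compound), compound 1 `Cc1c(-c2nnc(-c3ccccc3)o2)sc2ncnc(N3CCCCC3)c12` gives 22.1 ug/mL and compound 2 `Cc1c(-c2nnc(-c3ccc([N+](=O)[O-])cc3)o2)sc2ncnc(N3CCCCC3)c12` gives 11.9 ug/mL on the same read-out, so compound 2 stands within the scatter of its only measured neighbour. Compound 3 `Cc1c(-c2nnc(-c3ccc(Cl)cc3)o2)sc2ncnc(N3CCCCC3)c12` has chloro in place of nitro on an aromatic carbon, para to a large group (chloro in place of nitro on an aromatic carbon). Among the measured compounds shown here, the only measured step at this place, nitro in place of hydrogen, is a 1.9-fold lower number from compound 1 to compound 2 (0.27 log units; within the scatter) and does not separate the two compounds. No change beyond the scatter is therefore expected in this assay and the estimated step is a 1.3-fold higher number from compound 2 to compound 3 (0.10 log units; within the scatter) on this basis. Compound 3 is expected at 15 ug/mL with an estimated range from 7 ug/mL to 32 ug/mL on this read-out.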

Compound 3, half-maximal effective concentration: 21.8 ug/mL
Compound 3: the middle estimate sits 1.5-fold (0.16 log units) below what was measured; low and high end bracket the measured number.
By their numbers in this assay, from the lowest: compounds 2, 3 and 1 (each within the scatter of the next).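

In this assay, chloro in place of nitro gives a small step (a 1.8-fold higher number from compound 2 to compound 3 (0.26 log units; within the scatter)), and chloro in place of hydrogen gives another (a 1.0-fold lower number from compound 1 to compound 3 (0.01 log units; within the scatter)). Hydrogen, nitro and chloro on this aromatic carbon, para to a large group, therefore stay within the scatter of one another across these three compounds, and no substituent shown here separates from the rest. No available evidence bears on this result. Going by these compounds, whether an amine or a carboxylic acid on this carbon would move the number beyond the scatter remains open, as does the effect of a change elsewhere on the shared core.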